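The source may hold more compounds than are shown below. What is called first, only, known or untested is meant among the compounds shown, and "the series" means these compounds.

Of the compounds shown here, three built on one shared core have been tested in a functional assay on Vas deferens for antagonist activity at Alpha-1A adrenergic receptor (Rattus norvegicus); a higher number here means a more potent compound, by a factor of ten per unit of this negative logarithm, a lower number a less potent compound. Compound 1 `COc1cccc(OC)c1OCCNCCOc1ccccc1OCc1ccccc1Cl` gives 8.56, compound 2 `COc1cccc(OC)c1OCCNCCOc1ccccc1OCc1ccc(C)cc1` gives 8.23, and compound 3 `COc1cccc(OC)c1OCCNCCOc1ccccc1OCc1ccc([N+](=O)[O-])cc1` gives 8.58. Compound 3 holds the highest of the three numbers, although a number 0.02 log units higher from compound 1 to compound 3 (within the scatter) lies within the scatter, whereas a number 0.33 log units lower from compound 1 to compound 2 (beyond the scatter) is a modest loss. Compound 4 `CCOc1ccc(COc2ccccc2OCCNCCOc2c(OC)cccc2OC)cc1` differs from compound 3 by ethoxy in place of nitro on an aromatic carbon. The step that bears on this change is a number 0.35 log units higher from compound 2 to compound 3 (beyond the scatter), a modest gain beyond the scatter; removing the nitro again runs that step in reverse, so a modest drop in this assay is expected. Compound 4 is therefore estimated at 8.3, within 7.9 to 8.7. That expectation amounts to an estimated a number 0.28 log units lower from compound 3 to compound 4 (within the scatter).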

Compound 4, negative logarithm of the antagonist equilibrium constant: 8.5
The estimate for compound 4 lay 0.20 log units below the measured number; measured number inside the range.
By their numbers in this assay, from the lowest: compounds 2, 4, 1 and 3 (each within the scatter of the next, the first and the last beyond it).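

In this assay ethoxy replaces nitro on this aromatic carbon, para to a large group, with a number 0.08 log units lower from compound 3 to compound 4 (within the scatter) as the step, so the two groups cannot be told apart here. Nor can 4-ethoxyphenyl be told apart from 4-methylphenyl, with a number 0.27 log units higher from compound 2 to compound 4 (within the scatter) as the step, or from 2-chlorophenyl, with a number 0.06 log units lower from compound 1 to compound 4 (within the scatter) as the step, even though methyl and nitro do differ beyond the scatter. No measurement offered here explains these results.

Going by these compounds, whether an amine, a carboxylic acid or a chain longer than ethoxy on this carbon would keep the number in the same range remains open.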